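Side-chain variation on the shared core: expectations for compound 4

This account rests on a few compounds, and the source may have more. Where it says the series, first, only, none or still open, it means among the compounds named here.

Measured so far in a functional assay on HeLa cells (Homo sapiens) for cytotoxicity, read by MTT assay; on this read-out higher numbers stand for weaker inhibition and lower numbers for stronger inhibition:
compound 1 `CCC(C)(O)CC(=O)O[C@H](CC=C(C)C)C1=CC(=O)c2c(O)ccc(O)c2C1=O`, 25200 nM
compound 2 `CC(C)=CC[C@@H](OC(=O)C1CCCO1)C1=CC(=O)c2c(O)ccc(O)c2C1=O`, 17000 nM
compound 3 `CC(C)=CC[C@@H](OC(=O)c1ccco1)C1=CC(=O)c2c(O)ccc(O)c2C1=O`, 80300 nM

Compound 1 has the second highest of the three numbers; its nearest neighbour is compound 2, a 1.5-fold lower number from compound 1 to compound 2 (0.17 log units; within the scatter), and its furthest is compound 3, a 3.2-fold higher number from compound 1 to compound 3 (0.50 log units; beyond the scatter). Among compounds 2 and 3, a 4.7-fold higher number from compound 2 to compound 3 (0.67 log units; beyond the scatter).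

Compound 4 `CC(=O)OC(C)CO[C@H](CC=C(C)C)C1=CC(=O)c2c(O)ccc(O)c2C1=O` is not yet measured. It differs from compound 1 as follows: 2-acetoxypropyl in place of (2-hydroxy-2-methylbutyl)carbonyl on an oxygen on a saturated carbon. The measured steps all swap groups on a carbonyl carbon and leave the oxygen on a saturated carbon untouched, so they bear only loosely on this change; they show steps from within the scatter to modest size, with no large jumps. For compound 4 a step of about a 1.0-fold lower number from compound 1 to compound 4 (0.00 log units; within the scatter) is therefore expected, within the scatter, and the estimate for compound 4 in this assay is 25000 nM, ranging from 8000 nM to 80000 nM.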

Compound 4, half-maximal inhibitory concentration: 40100 nM
Beside the measured number, compound 4's estimate is 1.6-fold (0.21 log units) below it; measured number inside the range.
By their numbers in this assay, from the lowest: compounds 2, 1, 4 and 3 (each within the scatter of the next, the first and the last beyond it).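

In this assay, among the compounds shown here, exchanging (2-hydroxy-2-methylbutyl)carbonyl for 2-acetoxypropyl on an oxygen on a saturated carbon gives a first change at this oxygen itself, and it loses the hydrogen-bond donor of the leaving group, yet the step stays small (a 1.6-fold higher number from compound 1 to compound 4 (0.20 log units; within the scatter)). Against the other two groups, the steps are a 2.0-fold lower number from compound 3 to compound 4 (0.30 log units; within the scatter) and a 2.4-fold higher number from compound 2 to compound 4 (0.37 log units; beyond the scatter), so only the comparison with compound 2 passes the scatter. Nothing available explains these steps.

Going by these compounds, whether an amine or a carboxylic acid in place of the acetoxy end would move the number stays open. So does the effect of a longer chain at this oxygen.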